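This account rests on a few compounds, and the source may have more. Where it says the series, first, only, none or still open, it means among the compounds named here.

Values in a functional assay on DU-145 cells (Homo sapiens) for inhibition, read by trypan blue exclusion, with a stated time of 72 h; a lower number here means a stronger inhibitor, a higher number a weaker inhibitor:
- compound 1 `Cn1c(=O)c(S(=O)(=O)c2ccc(F)cc2F)cc2cnc(Nc3cccc4[nH]ccc34)nc21`: 750 nM
- compound 2 `Cn1c(=O)c(S(=O)(=O)c2ccc(F)cc2F)cc2cnc(Nc3ccc4[nH]ncc4c3)nc21`: 30000 nM
- compound 3 `Cc1ccc(S(=O)(=O)c2cc3cnc(Nc4cnc5[nH]ccc5c4)nc3n(C)c2=O)cc1`: 25000 nM

In this assay compound 3 gives 25000 nM, within the scatter of compound 2 and far higher than compound 1. Compound 4 `Cn1c(=O)c(S(=O)(=O)c2ccc(F)cc2F)cc2cnc(Nc3cnc4[nH]ccc4c3)nc21` differs from compound 3 in one place: 2,4-difluorophenyl in place of 4-methylphenyl on a sulfonyl sulfur. For the measured compounds named here, the only measured step, a 40-fold higher number from compound 1 to compound 2 (1.60 log units; beyond the scatter), is large, but it concerns the group on a nitrogen, not the group on the sulfonyl sulfur, so no measured step tests this change directly. Compound 2, which also carries 2,4-difluorophenyl, gives 30000 nM, so no shift beyond the scatter is expected. The estimated step is a 1.3-fold lower number from compound 3 to compound 4 (0.10 log units; within the scatter). Compound 4 is expected at 20000 nM, with an estimated range of 6000 nM to 60000 nM.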

Compound 4, half-maximal inhibitory concentration: 750 nM
Beside the measured number, compound 4's estimate is 27-fold (1.43 log units) above it; measured number below the stated range.
By their numbers in this assay, from the lowest: compounds 1 and 4 (each within the scatter of the next); then compounds 3 and 2 (each within the scatter of the next).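

In this assay the group on the sulfonyl sulfur clearly matters: 2,4-difluorophenyl in place of 4-methylphenyl gives a large step (a 33-fold lower number from compound 3 to compound 4 (1.52 log units; beyond the scatter)). That group alone does not set the result, since the group on the nitrogen also counts in both a large step (a 40-fold lower number from compound 2 to compound 4 (1.60 log units; beyond the scatter)) and a step within the scatter (no change at the digits printed from compound 1 to compound 4 (within the scatter)). Nothing available explains these differences.

Still open, on these data alone, is whether 4-fluorophenyl or plain phenyl on the sulfonyl sulfur would match 2,4-difluorophenyl. Also open, as far as these compounds go, is whether the sulfonyl change has the same effect with the nitrogen groups of compound 1 or compound 2.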